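The source may hold more compounds than are shown below. What is called first, only, known or untested is meant among the compounds shown, and "the series" means these compounds.

Working notes on the series. Of the compounds shown here, two have numbers so far. Compound 1 `CN(C)C(=O)n1cc(C(=O)c2ccn3c2CSC3c2cccnc2)c2ccc(Sc3ccc(F)cc3)cc21` gives 17 nM in a functional assay (Oryctolagus cuniculus) for antagonist activity at platelet-activating factor receptor (Cavia porcellus); a higher number here means a weaker inhibitor, a lower number a stronger inhibitor. Compound 2 `Cn1cc(C(=O)c2ccn3c2CSC3c2cccnc2)c2ccc(-c3ccc(F)cc3)cc21` gives 7 nM in this assay, the lower of the two numbers, and the gap to compound 1 lies beyond the scatter, so compound 2 stands as the stronger inhibitor of this pair. The two differ in more than one place, so nothing is read into the gap beyond what the two values show.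

Compound 3 `O=C(O)CCn1cc(C(=O)c2ccn3c2CSC3c2cccnc2)c2ccc(-c3ccc(F)cc3)cc21` has not been measured. Compared with compound 2 the change is carboxymethyl in place of hydrogen on a saturated chain carbon bound to an aromatic nitrogen. Going by the values given here, no step between measured compounds in this assay bears on this change, so no measured step guides the expectation. The expected step from compound 2 to compound 3 is a 2.1-fold higher number from compound 2 to compound 3 (0.33 log units; beyond the scatter), a modest rise, possibly within the scatter. Compound 3 is estimated at 15 nM in this assay, with a range from 4 nM to 60 nM.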

Compound 3, inhibition constant: 160 nM
The estimate for compound 3 lay 11-fold (1.03 log units) below the measured number, and the stated range ends below it.
By their numbers in this assay, from the lowest: compound 2; then compound 1; then compound 3.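

Going by these compounds alone, the change from methyl to 2-carboxyethyl, on a saturated chain carbon bound to an aromatic nitrogen, is the first single-place comparison, and in this assay it gives a 23-fold higher number from compound 2 to compound 3 (1.36 log units; beyond the scatter). This position is therefore not indifferent to what it carries, although compound 3 still gives a measurable inhibition constant of 160 nM. No measurement on hand accounts for the size of this step.

The compounds shown do not separate the contribution of the carboxylic acid from that of the longer chain, so a plain propyl chain, a methyl ester or a primary amide at the same place would each bear on that question. Also open, going by these compounds, is whether an amine on the same chain would be tolerated as well as the methyl of compound 2.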